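The compounds below may be only part of what the source reports. "The series", "measured", "known", "first", "only" and "open" are said of these compounds alone.

Series values in a functional assay on A549 cells (Homo sapiens) for inhibition, read by MTT assay, with a stated time of 72 h; a higher number here means a weaker inhibitor, a lower number a stronger inhibitor:
- compound 1 `CCc1nc2c(C)cc(-c3ccc(CN4CCC(O)CC4)cc3)cn2c1NC(=O)OCc1cc(Cl)cc(Cl)c1`: "nd" (no result reported)
- compound 2 `CCc1nc2c(C)cc(-c3ccc(CN4CCN(C)CC4)cc3)cn2c1NC(=O)OCc1cc(Cl)cc(Cl)c1`: 4020 nM

In this assay compound 1 stands at "nd" (no result reported), so no result is reported and it offers no number to start from. For the measured compounds named here, the only anchor is compound 2 at 4020 nM. Compound 3 `CCc1nc2c(C)cc(-c3ccc(CNCCO)cc3)cn2c1NC(=O)OCc1cc(Cl)cc(Cl)c1` follows from compound 1 through ((2-hydroxyethyl)amino in place of 4-hydroxypiperidin-1-yl on a saturated chain carbon bound to an aromatic carbon). Going by the values given here, no measured step is available to size this change, so the expectation for compound 3 rests on the level of compound 2 at 4020 nM, and no direction is favoured. For compound 3 the estimated value is 4000 nM, with an expected range of 1500 nM to 11000 nM.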

Compound 3, half-maximal inhibitory concentration: > 20000 nM
Compound 3 gave a limit, no number; the forecaster's own chance of this, stated with the estimate: 10%; at least 5.0-fold (0.69 log units) between middle value and limit.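

In this assay, for the compounds shown here, putting (2-hydroxyethyl)amino in place of 4-methylpiperazin-1-yl on a saturated chain carbon bound to an aromatic carbon gives an at least 4.9-fold higher number from compound 2 to compound 3 (0.69 log units; beyond the scatter), the first sized change at this position and one towards weaker inhibition. For compound 3 the result is a limit and not a number: the limit of > 20000 nM in this assay, at which 1 of the 3 values shown sits. The step from compound 1 to compound 3 cannot be read.

From the compounds shown here alone, how far compound 3 lies past its limit stays open. Also open, going by these compounds, is whether a morpholine ring or a dimethylamino group at this place would hold the level of compound 2.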